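Replacing tert-butyl with methoxymethyl: an expected fall

This account rests on a few compounds, and the source may have more. Where it says the series, first, only, none or still open, it means among the compounds named here.

Compound 1 (`C#CCCCC[n+]1ccn(C)c1/C=N/O`) gives -2.02 in a physicochemical assay for lipophilicity; a higher number here means a more lipophilic compound, a lower number a more polar compound
Compound 2 (`C#CCCCC[n+]1ccn(C(C)(C)C)c1/C=N/O`) gives -1.42 in this assay

For the measured compounds named here, compound 2 stands highest of the two measured compounds in this assay and compound 1 is the nearest to it, with a number 0.60 log units higher from compound 1 to compound 2 (beyond the scatter) as the one measured step, a modest one beyond the scatter. Compound 3 (`C#CCCCC[n+]1ccn(COC)c1/C=N/O`) differs from compound 2 through methoxymethyl in place of tert-butyl on an aromatic nitrogen as methoxymethyl in place of tert-butyl on an aromatic nitrogen. Going by the values given here, the measured step, tert-butyl in place of methyl on an aromatic nitrogen, is the only one bearing on this change, so a step of similar size towards a lower number is expected in this assay. The expected step is a number 0.63 log units lower from compound 2 to compound 3 (beyond the scatter) in this estimate. For compound 3 the estimated value is -2.05 with an expected range from -2.45 to -1.7 in this assay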

Compound 3, distribution coefficient: -1.71
Compound 3: the middle estimate sits 0.34 log units below what was measured; the measured number falls inside the stated range.
By their numbers in this assay, from the lowest: compound 1; then compounds 3 and 2 (each within the scatter of the next).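

In this assay, a number 0.29 log units lower from compound 2 to compound 3 (within the scatter), so at this aromatic nitrogen methoxymethyl cannot be told apart from tert-butyl, even though it brings a hydrogen-bond acceptor that tert-butyl lacks. Yet a number 0.31 log units higher from compound 1 to compound 3 (beyond the scatter), which leaves compound 1 apart from both other compounds. Nothing available here accounts for this result. What the compounds shown leave open is how far these numbers reach beyond these three groups: an amine, a carboxylic acid or a longer ether chain on the same nitrogen could each give a different reading.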